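Notes on the step from compound 3 to compound 4

This account rests on a few compounds, and the source may have more. Where it says the series, first, only, none or still open, it means among the compounds named here.

Compound 1 `Cc1c(Cc2c(F)cccc2F)nc(Nc2ccc(C#N)cc2)[nH]c1=O`, compound 2 `Cc1cnc(Nc2ccc(C#N)cc2)nc1C(C)c1c(F)cccc1F` and compound 3 `Cc1c(C(C)c2c(F)cccc2F)nc(Nc2ccc(C#N)cc2)[nH]c1=O` have been run in an ADME assay on MT4 cells (Homo sapiens) for cytotoxicity, read by MTT assay; on this read-out lower numbers stand for higher toxicity in this test and higher numbers for lower toxicity in this test. In this assay compound 1 gives > 2830 nM, which is a limit of the assay rather than a number. Compound 2 gives 71400 nM. Compound 3 gives 1060 nM and so stands lowest of the two numbers, with compound 2 as its nearest neighbour at a much higher value, a gap beyond the scatter. Among the compounds with values here, the only measured step, an at least 2.6-fold lower number from compound 1 to compound 3 (0.42 log units; beyond the scatter), concerns a methyl on the saturated chain carbon and nothing else.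

Compound 4 `Cc1c(C(C)c2c(F)cccc2F)nc(N(C)C)[nH]c1=O` differs from compound 3 by dimethylamino in place of (4-cyanophenyl)amino on an aromatic carbon. Within the data shown here, no measured step touches this part of the structure, so the expectation rests on the change itself: the six-membered aromatic ring and the nitrile are lost and a much smaller group enters, and a higher number in this assay is expected, though with a wide range. Compound 4 is expected to give about 10000 nM, within 2500 nM to 50000 nM, corresponding to an expected step of a 9.4-fold higher number from compound 3 to compound 4 (0.97 log units; beyond the scatter).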

Compound 4, half-maximal cytotoxic concentration: > 17000 nM
Compound 4: a limit, no number; the forecaster's own chance of this, stated with the estimate: 30%; middle value at least 1.7-fold (0.23 log units) away from the limit.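

In this assay, within the data shown here, this is the first measured change at the position between two ring nitrogen atoms, and it is large: dimethylamino in place of (4-cyanophenyl)amino gives an at least 16-fold higher number from compound 3 to compound 4 (1.20 log units; beyond the scatter). Compound 4 gives > 17000 nM, which is a limit of the assay and not a number: the limit of > 17000 nM in this assay, at which 1 of the 4 values shown sits. The low number of compound 3 therefore does not persist once (4-cyanophenyl)amino leaves, so this position matters to the read-out as well as the methyl on the chain carbon.

Going by these compounds, the step removes the six-membered aromatic ring, the nitrile and the amino hydrogen together, so which of these goes with the low number stays open. A phenylamino group without the nitrile, or morpholine at the same place, would separate these parts.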